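Quinolin-2-yl amide on an ethylpiperazinyl quinoline core

A few compounds are considered here, and "the series" means these few. Any claim that something is new, unique, unknown or untested is made for them only; others in the source may bear on it.

Measured compounds:
compound 1, `CNc1cc(C)c2cc(NC(=O)c3ccc(Cl)c(Cl)c3)ccc2n1`, 2520 nM
compound 2, `CCN1CCN(c2cc(C)c3cc(NC(=O)c4cccc(Cl)c4)ccc3n2)CC1`, 3820 nM

Both compounds were tested in a functional assay on MCF7 cells (Homo sapiens) for antiproliferative activity, read by MTT assay, with a stated time of 72 h; on this read-out lower numbers stand for stronger inhibition and higher numbers for weaker inhibition. Compound 1 gives 2520 nM, and compound 2 gives 3820 nM; the two values lie within the usual scatter of each other, so the numbers show no separation between them.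

Compound 3, `CCN1CCN(c2cc(C)c3cc(NC(=O)c4ccc5ccccc5n4)ccc3n2)CC1`, has not yet been measured in this assay. Compared with compound 2 it differs in one place: quinolin-2-yl in place of 3-chlorophenyl on a carbonyl carbon. Among the measured compounds shown here, no pair of measured compounds shows a step of this kind, so there is no measured step on which to rest a direction. With only the two values of compound 1 and compound 2 to go by, no step beyond the scatter is expected; the value of compound 3 in this assay is estimated at 3500 nM, with a range from 900 nM to 14000 nM. The step this estimate means is a 1.1-fold lower number from compound 2 to compound 3 (0.04 log units; within the scatter), an expected change no larger than the scatter.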

Compound 3, half-maximal inhibitory concentration: 7060 nM
Compound 3: middle estimate off by 2.0-fold (0.30 log units), on the low side; low and high end bracket the measured number.
By their numbers in this assay, from the lowest: compounds 1, 2 and 3 (each within the scatter of the next, the first and the last beyond it).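

In this assay, putting quinolin-2-yl in place of 3-chlorophenyl on a carbonyl carbon gives a 1.8-fold higher number from compound 2 to compound 3 (0.27 log units; within the scatter), so the numbers do not separate the two compounds. This first step read at this position shows that it accepts the fused aromatic group, with its ring nitrogen and hydrogen-bond acceptor, and the chlorine-bearing ring is not required to keep a value in the same range as that of compound 2. No measurement shown here accounts for the small difference that remains between the two values.

Going by these compounds, whether an unsubstituted phenyl, a pyridin-2-yl or a saturated ring such as cyclohexyl on the same carbonyl carbon would move the number beyond the scatter remains open. Among the compounds shown here, no single-place step shows what the ethylpiperazinyl group contributes, so its replacement by a morpholine or a piperidine is also an open question.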